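This account rests on a few compounds, and the source may have more. Where it says the series, first, only, none or still open, it means among the compounds named here.

- compound 1 `Oc1cccc2[nH]c(-c3ccc(-c4ccc(-c5ccc(F)cc5)cc4)cc3)nc12` gives 1220 nM in a functional assay on COLO 205 cells (Homo sapiens) for inhibition, read by sulforhodamine B assay; on this read-out lower numbers stand for stronger inhibition of growth and higher numbers for weaker inhibition of growth
- compound 2 `Oc1cccc2[nH]c(-c3ccc(-c4ccc(-c5ccc(C(F)(F)F)cc5)cc4)cc3)nc12` gives 3410 nM in this assay

Compound 2 holds the higher of these two numbers, and compound 1 is its nearest neighbour. Still unmeasured is compound 3 `Oc1ccc(-c2ccc(-c3ccc(-c4nc5c(O)cccc5[nH]4)cc3)cc2)cc1`, which has hydroxy in place of trifluoromethyl on an aromatic carbon, para to a large group (hydroxy in place of trifluoromethyl on an aromatic carbon). For the measured compounds named here, one measured step bears on this change, trifluoromethyl in place of fluoro on an aromatic carbon (a 2.8-fold higher number from compound 1 to compound 2 (0.45 log units; beyond the scatter)), a modest step beyond the scatter. Going by the values given here, no measured compound carries hydroxy, so the guide is thin. Since compound 3 gives up the trifluoromethyl that came with the higher number in that step, a modest move towards lower numbers is expected in this assay here. The expected step is a 2.8-fold lower number from compound 2 to compound 3 (0.45 log units; beyond the scatter) by this estimate. For compound 3 the estimated value is 1200 nM (from 350 nM to 3500 nM).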

Compound 3, concentration for 50% growth inhibition: 2600 nM
Estimate against measurement, compound 3: 2.2-fold (0.34 log units) below, and the stated range covers the measured number.
By their numbers in this assay, from the lowest: compound 1; then compounds 3 and 2 (each within the scatter of the next).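

In this assay, hydroxy in place of trifluoromethyl, on an aromatic carbon para to a large group, gives a 1.3-fold lower number from compound 2 to compound 3 (0.12 log units; within the scatter), so at this position compound 3 and compound 2 cannot be told apart, although the two groups differ in their atoms and in their hydrogen-bond donor and acceptor counts. Hydroxy in place of fluoro at the same place gives a 2.1-fold higher number from compound 1 to compound 3 (0.33 log units; beyond the scatter), which leaves compound 1, with fluoro, apart from both of the others, and the step from fluoro is now seen with two different groups rather than one. Nothing available here accounts for this result.

The compounds shown leave open whether an amine, a carboxylic acid or a methoxy group at this place would read nearer compound 1 or nearer the other two. They also leave open whether chloro, as another halogen, would stay close to fluoro.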